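Benzyl methyl position in the N-alkyl series

This account rests on a few compounds, and the source may have more. Where it says the series, first, only, none or still open, it means among the compounds named here.

Measured so far:
compound 1 `CCCCN(CC)c1cc(C)nc2c(-c3cnc(N(C)C)cc3C)c(C)nn12`, 2.6 nM
compound 2 `CCN(Cc1cccc(C)c1)c1cc(C)nc2c(-c3cnc(N(C)C)cc3C)c(C)nn12`, 2.4 nM

In an assay on CHO cells for binding affinity to corticotropin-releasing factor receptor 1 (Homo sapiens) (a lower number here means a stronger inhibitor, a higher number a weaker inhibitor), compound 1 gives 2.6 nM and compound 2 gives 2.4 nM. For the measured compounds named here, the only step so far, a 1.1-fold lower number from compound 1 to compound 2 (0.03 log units; within the scatter), is within the scatter, so compound 2 stands at the lower of the two numbers without being separated from compound 1. Compound 3 `CCN(Cc1ccc(C)cc1)c1cc(C)nc2c(-c3cnc(N(C)C)cc3C)c(C)nn12` differs from compound 2 by 4-methylphenyl in place of 3-methylphenyl on a saturated chain carbon bound to a nitrogen on an aromatic ring. Going by the values given here, no measured step concerns the position of the methyl on the benzyl ring; the step from compound 1 to compound 2 shows only that the site bound to the ring nitrogen accepts a propyl chain and a 3-methylbenzyl alike. Compound 3 is therefore expected to stay close to compound 2, with a 1.3-fold higher number from compound 2 to compound 3 (0.10 log units; within the scatter) not beyond the scatter in either direction. The estimate for compound 3 in this assay is 3 nM, within 1.2 nM to 8 nM.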

Compound 3, inhibition constant: 2.3 nM
For compound 3 the middle estimate is 1.3-fold (0.12 log units) above the measured one; the range from low to high includes it.
By their numbers in this assay, from the lowest: compounds 3, 2 and 1 (each within the scatter of the next).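

In this assay, 4-methylphenyl in place of 3-methylphenyl on a saturated chain carbon bound to a nitrogen on an aromatic ring gives a 1.0-fold lower number from compound 2 to compound 3 (0.02 log units; within the scatter) and leaves the two methyl placements unseparated. The comparison with the propyl end of the chain gives a 1.1-fold lower number from compound 1 to compound 3 (0.05 log units; within the scatter) and also lies within the scatter, so compounds 1, 2 and 3 read alike at this place in this assay. No measured evidence bears on this result.

The compounds shown carry only a methyl on the benzyl ring, so they leave open whether a 4-methoxybenzyl or a 4-chlorobenzyl would read the same. They also leave open whether a benzyl ring carrying an amine or a carboxylic acid would stay level with compounds 1, 2 and 3.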